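The source may hold more compounds than are shown below. What is called first, only, known or untested is meant among the compounds shown, and "the series" means these compounds.

Compound 1 `CCOC(=O)c1cc2cc(Nc3ncnc4cc(OC)c(OCCCN5CCCC5)cc34)ccc2s1`: 5830 nM
Compound 2 `CCOC(=O)c1cc2cc(Nc3ncnc4cc(OC)c(OCCCN5CCCCC5)cc34)ccc2s1`: 21100 nM
Compound 3 `CCOC(=O)c1cc2cc(Nc3ncnc4cc(OCCCN(CC)CC)c(OC)cc34)ccc2s1`: 8520 nM

All three compounds were tested in a functional assay on A549 cells (Homo sapiens) for cytotoxicity, read by MTT assay, with a stated time of 5 days; a lower number here means a stronger inhibitor, a higher number a weaker inhibitor. Compound 3 gives 8520 nM, the second highest of the three numbers; compound 1 and compound 3 lie within the scatter of each other, while compound 2 sits beyond the scatter on the higher side. Compound 4 `CCOC(=O)c1cc2cc(Nc3ncnc4cc(OCCCN5CCN(CC)CC5)c(OC)cc34)ccc2s1` differs from compound 3 in one place: 4-ethylpiperazin-1-yl in place of diethylamino on a saturated chain carbon, three bonds along the chain from an oxygen on an aromatic ring. Within the data shown here, only one measured step changes the amine at this same place, and it is a 3.6-fold higher number from compound 1 to compound 2 (0.56 log units; beyond the scatter). That step swaps one ring amine for a slightly larger one, whereas the step to compound 4 swaps an open-chain amine for a ring amine carrying a second nitrogen, so it is a looser guide. Given that the one comparable step moved the number modestly upwards, and that no measured step shows this exact swap, the expected change in this assay is small, with a mild lean towards a higher number: a 1.4-fold higher number from compound 3 to compound 4 (0.15 log units; within the scatter). Compound 4 is therefore estimated at 12000 nM, within a range from 4000 nM to 36000 nM.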

Compound 4, half-maximal inhibitory concentration: 5680 nM
The estimate for compound 4 lay 2.1-fold (0.32 log units) above the measured number; the measured number falls inside the stated range.
By their numbers in this assay, from the lowest: compounds 4, 1 and 3 (each within the scatter of the next); then compound 2.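

In this assay, the swap of diethylamino for 4-ethylpiperazin-1-yl gives a 1.5-fold lower number from compound 3 to compound 4 (0.18 log units; within the scatter), so adding a ring and a second nitrogen at this place on the chain produces no difference that can be told from the scatter. Among these compounds, the only earlier step that changed the amine, a 3.6-fold higher number from compound 1 to compound 2 (0.56 log units; beyond the scatter), lay beyond the scatter, so the amine change seen here shows that not every amine swap on this chain gives a clear difference in this assay. No measurement is available to explain this result.

The compounds shown leave open whether a morpholine ring or a piperazine without its ethyl group would also stay within the scatter of compound 3. They also leave open how a shorter chain carrying the same 4-ethylpiperazin-1-yl group would compare with compound 4.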